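The source may report more compounds than this note shows. Statements on the series, on what has been measured and on what is new or still open speak of the compounds shown alone.

Compound 1, with the structure `Cc1cc(O)c(C(=S)Nc2ccccc2)c(=O)o1`, is one of three compounds examined in an ADME assay on L929 cells (Mus musculus, culture collection number NCTC 929) for cytotoxicity, read by MTT assay, with a stated time of 72 h; a lower number here means a stronger inhibitor, a higher number a weaker inhibitor. In this assay compound 1 gives > 200000 nM, which is a limit of the assay rather than a number. Compound 2, with the structure `CCCCCCCCCCCCCCNC(=O)c1c(O)cc(C)oc1=O`, is also reported only as a limit in this assay, namely > 200000 nM. Compound 3, with the structure `CCCCCCCCCCc1c(O)cc(C)oc1=O`, is the only one of the three with a numeric reading, giving 56000 nM in this assay. Going by the values given here, compound 1 therefore stands at the limit of > 200000 nM in this assay, at which 2 of the 3 values shown sit, so no step between measured compounds can be stated in numbers.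

The compound that follows is compound 4, with the structure `Cc1cc(O)c(C(=S)NC2CCCCC2)c(=O)o1`. It differs from compound 1 by the change (cyclohexyl in place of phenyl on an amide-type nitrogen). Since compound 1 sits at the limit, the step from compound 1 to compound 4 in this assay is expected to stay within the scatter, as a number no higher from compound 1 to compound 4 (the limit leaves the size open). Compound 4 is therefore estimated at 200000 nM in this assay, within a range from 100000 nM to 400000 nM, most likely reported again as a limit.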

Compound 4, half-maximal inhibitory concentration: 177000 nM
Compound 4: middle estimate off by 1.1-fold (0.05 log units), on the high side; the range from low to high includes it.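

On the amide-type nitrogen next to the thiocarbonyl carbon, compound 4 gives 177000 nM in this assay, so this series now has a numeric reading. Cyclohexyl in place of phenyl gives an at least 1.1-fold lower number from compound 1 to compound 4 (0.05 log units; that floor lies within the scatter), which shows that exchanging the aromatic ring for the non-aromatic ring of the same size does not produce a step known to lie beyond the scatter. The true size of the step stays unknown because compound 1 is reported only as a limit: the limit of > 200000 nM in this assay, at which 2 of the 4 values shown sit.

The compounds shown leave open how a benzyl group, a morpholine ring or a chain ending in a carboxylic acid would read on this nitrogen. They also leave open whether a fluorine or an amine on the phenyl ring would bring compound 1's series to a numeric reading.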